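This account rests on a few compounds, and the source may have more. Where it says the series, first, only, none or still open, it means among the compounds named here.

Measured in a functional assay on HepG2 cells (Homo sapiens) for cytotoxicity, read by MTT assay, with a stated time of 48 h; a lower number here means a stronger inhibitor, a higher number a weaker inhibitor:
compound 1 `Cc1ccc2oc(-c3ccccc3Cl)cc(=O)c2c1`: 6230 nM
compound 2 `CC[N+](CC)(CC)Cc1ccc2oc(-c3ccc([N+](=O)[O-])cc3)cc(=O)c2c1`: "not determined" (no result reported)
compound 3 `CC[N+](CC)(CC)Cc1ccc2oc(-c3ccc(Cl)cc3)cc(=O)c2c1`: "not determined" (no result reported)

Compound 3 has no place on the numbers: no result was reported for it in this assay, and the same holds for compound 2. Going by the values given here, that leaves a single number for the whole series, and no step between two measured compounds is available to calibrate the next one.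

The compound still to be measured is compound 4 `CC[N+](CC)(CC)Cc1ccc2oc(-c3ccccc3Cl)cc(=O)c2c1`. The change under consideration is 2-chlorophenyl in place of 4-chlorophenyl on an aromatic carbon, with the same atoms joined differently. The data give no measure of what such a move does in this assay. The working expectation is therefore no step beyond the scatter, with no direction favoured, although this cannot be checked while compound 3 lacks a number.

Among the compounds with values here, the only numerical anchor is compound 1 at 6230 nM, so the expected value is placed near it, with a wide range to reflect how little the series shows so far. For compound 4 the expected value is 8000 nM, with an estimated range of 2000 nM to 40000 nM.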

Compound 4, half-maximal inhibitory concentration: 61000 nM
Compound 4: middle estimate off by 7.6-fold (0.88 log units), on the low side, and the stated range ends below it.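

In this assay the series now holds one readable step, a 9.8-fold higher number from compound 1 to compound 4 (0.99 log units; beyond the scatter), for a group of 7 heavy atoms (6 carbon, 1 nitrogen; no ring) in place of a hydrogen atom on a saturated chain carbon bound to an aromatic carbon. With 2-chlorophenyl common to both compounds, this change gives a weaker inhibitor, the first direction shown at this position, although it rests on this one pair; the steps to compound 2 and compound 3 cannot be read, so the move from 4-chlorophenyl to 2-chlorophenyl still has neither size nor direction. No measurement shown here accounts for the size of the step.

Open, from the compounds shown here alone, is whether the step depends on this exact group: a diethylamino group, a carboxylic acid or a longer chain on the same carbon could give a different number. Also open, going by these compounds, is whether the step carries over to compounds with 4-chlorophenyl or 4-nitrophenyl in place of 2-chlorophenyl, or whether it belongs to this one pair alone.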